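A few compounds are considered here, and "the series" means these few. Any claim that something is new, unique, unknown or untested is made for them only; others in the source may bear on it.

Compound 3 `O=C(Nc1c(C(O)(C(F)(F)F)C(F)(F)F)ccc2ccccc12)c1ccc(F)cc1` carries a 4-fluorophenyl group on its carbonyl carbon. In an assay on LtK cells with ATP-sensitive inward rectifier potassium channel 11 (Homo sapiens) as the target (on this read-out lower numbers stand for an effect already at smaller amounts and higher numbers for an effect only at larger amounts of compound), compound 3 gives 70 nM, the second highest of the three numbers: compound 2 `O=C(Nc1c(C(O)(C(F)(F)F)C(F)(F)F)ccc2ccccc12)C1CCC1` gives 45 nM, and compound 1 `CC(C)C(=O)Nc1c(C(O)(C(F)(F)F)C(F)(F)F)ccc2ccccc12` gives 6630 nM. The steps of a 150-fold lower number from compound 1 to compound 2 (2.17 log units; beyond the scatter) and a 95-fold lower number from compound 1 to compound 3 (1.98 log units; beyond the scatter) were both large, while a 1.6-fold higher number from compound 2 to compound 3 (0.19 log units; within the scatter). Compound 4 `O=C(Nc1c(C(O)(C(F)(F)F)C(F)(F)F)ccc2ccccc12)c1cccc(Cl)c1Cl` differs from compound 3 in one place: 2,3-dichlorophenyl in place of 4-fluorophenyl on a carbonyl carbon. Within the data shown here, none of the measured steps exchanges one aryl group for another, so there is no direct guide; the closest comparison, that between compound 2 and compound 3, stayed within the scatter. Compound 4 is therefore expected to give about 60 nM, in a range of 15 nM to 250 nM. That would be an expected 1.2-fold lower number from compound 3 to compound 4 (0.07 log units; within the scatter), a step expected to stay within the scatter.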

Compound 4, half-maximal effective concentration: > 10000 nM
Compound 4 was reported as a limit; the forecaster's own chance of this, stated with the estimate: 3%; at least 160-fold (2.22 log units) between middle value and limit.
By their numbers in this assay, from the lowest: compounds 2 and 3 (each within the scatter of the next); then compound 1. At a limit, above all of these: compound 4.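

Compound 4 is reported only as a limit: the limit of > 10000 nM in this assay, at which 1 of the 4 values shown sits.

An aryl group on this carbonyl carbon therefore does not by itself give a low number: 2,3-dichlorophenyl in place of 4-fluorophenyl gives an at least 140-fold higher number from compound 3 to compound 4 (2.15 log units; beyond the scatter), and in place of cyclobutyl it gives an at least 220-fold higher number from compound 2 to compound 4 (2.34 log units; beyond the scatter). Against the isopropyl group the result is an at least 1.5-fold higher number from compound 1 to compound 4 (0.17 log units; that floor lies within the scatter), so the order of those two compounds cannot be settled.

On these data alone, whether an unsubstituted phenyl or a phenyl carrying a single chlorine would keep the number low stays open. So does the outcome with an amine on that ring.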